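Cyclopentyl in place of 2-methoxyethyl: a cytotoxicity estimate

This account rests on a few compounds, and the source may have more. Where it says the series, first, only, none or still open, it means among the compounds named here.

In a toxicity assay on A549 cells (Homo sapiens) for cytotoxicity, read by luminescence and CellTiter-Glo, with a stated time of 48 h (a higher number here means that more compound is tolerated, a lower number that less compound is tolerated), compound 1 `COCCCCOc1ccc(-c2nc3ncccn3c2NC2CCCCC2)cc1` gives 100000 nM as a measured number. Compound 2 `COCCOc1ccc(-c2nc3ncccn3c2NC2CCCCC2)cc1` stands at > 100000 nM as a limit of the assay and not a number. The measured step of a number no lower from compound 1 to compound 2 (the limit leaves the size open) touches the same chain but has no readable size and so sets no scale here. For the measured compounds named here, compound 3 `c1cnc2nc(-c3ccc(OC4CCCC4)cc3)c(NC3CCCCC3)n2c1` carries cyclopentyl in place of 2-methoxyethyl on an oxygen on an aromatic ring and no measured step covers this swap. Only a small move in this assay is expected, if any, toward a lower number. The expected step runs an at least 1.4-fold lower number from compound 2 to compound 3 (0.15 log units; that floor lies within the scatter) by this estimate. Compound 3 is estimated at 70000 nM with a range from 25000 nM to 100000 nM in all.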

Compound 3, half-maximal cytotoxic concentration: 39000 nM
The estimate for compound 3 lay 1.8-fold (0.25 log units) above the measured number, and the stated range covers the measured number.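

In this assay, the oxygen on the aromatic ring proved a place where the group can shift the tolerated concentration by a readable amount: cyclopentyl in place of 4-methoxybutyl gives a 2.6-fold lower number from compound 1 to compound 3 (0.41 log units; beyond the scatter). Cyclopentyl in place of 2-methoxyethyl points the same way, with an at least 2.5-fold lower number from compound 2 to compound 3 (0.40 log units; beyond the scatter). Compound 2 stands at a limit of the assay and not a number: the limit of > 100000 nM in this assay, at which 1 of the 3 values shown sits.

The compounds shown do not separate the effect of the cyclopentyl ring from that of losing the chain oxygen. They also leave open how an amine-bearing chain or a cyclohexyl group on this oxygen would read.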